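The source may hold more compounds than are shown below. What is called first, only, known or untested is meant among the compounds shown, and "the series" means these compounds.

Measured compounds:
- compound 1, `CCCCCN1CCC(NC(=O)c2cc(Cl)c(N)cc2OC)CC1`, in a functional assay on HEK293 cells for agonist activity at 5-hydroxytryptamine receptor 4 (Homo sapiens), read by cAMP accumulation (a lower number here means that less compound is needed, a higher number that more compound is needed for the effect), gives 25.1 nM
- compound 2, `COc1cc(N)c(Cl)cc1C(=O)NC1CCN(CCCCCO)CC1`, in this assay gives 15.9 nM
- compound 3, `COc1cc(N)c(Cl)cc1C(=O)NC1CCN(CCCCCCCCO)CC1`, in this assay gives 15.9 nM

Compound 3 stands level with compound 2 at the digits shown, and the two together hold the lowest numbers of the three. Its nearest neighbour is compound 2, the step of no change at the digits printed from compound 2 to compound 3 (within the scatter); the furthest is compound 1, the step of a 1.6-fold lower number from compound 1 to compound 3 (0.20 log units; within the scatter). Compound 4, `COc1cc(N)c(Cl)cc1C(=O)NC1CCN(CCCCCN2C(=O)c3ccccc3C2=O)CC1`, is still to be measured in this assay. It differs from compound 3 in one place: a group of 11 heavy atoms (8 carbon, 1 nitrogen, 2 oxygen; one five-membered non-aromatic ring with 1 hetero atom, one six-membered aromatic ring of carbon only) in place of a group of 4 heavy atoms (3 carbon, 1 oxygen; no ring), on a saturated chain carbon, five bonds along the chain from an amine nitrogen in a ring.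

Within the data shown here, the steps that bear on the chain end are a 1.6-fold lower number from compound 1 to compound 2 (0.20 log units; within the scatter), a 1.6-fold lower number from compound 1 to compound 3 (0.20 log units; within the scatter) and no change at the digits printed from compound 2 to compound 3 (within the scatter): every one of them stays within the scatter. Among the measured compounds shown here, none of the measured compounds carries a ring at that position, so the change to compound 4 goes further than anything seen so far, and no measured step can be read as a direct precedent. On the evidence of the chain-end changes, the step of a 1.3-fold higher number from compound 3 to compound 4 (0.10 log units; within the scatter) is expected to stay within the scatter. Compound 4 is therefore estimated at 20 nM, with a range from 6 nM to 80 nM.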

Compound 4, half-maximal effective concentration: 5.01 nM
Beside the measured number, compound 4's estimate is 4.0-fold (0.60 log units) above it; the measured number lies below the stated range.
By their numbers in this assay, from the lowest: compound 4; then compounds 2, 3 and 1 (each within the scatter of the next).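

In this assay, the group carrying one five-membered non-aromatic ring with 1 hetero atom and one six-membered aromatic ring of carbon only gives a 3.2-fold lower number from compound 3 to compound 4 (0.50 log units; beyond the scatter), a 3.2-fold lower number from compound 2 to compound 4 (0.50 log units; beyond the scatter) and a 5.0-fold lower number from compound 1 to compound 4 (0.70 log units; beyond the scatter), each beyond the scatter, whereas the steps among the hydrogen, hydroxy and 3-hydroxypropyl compounds all stayed within it. The number at this position, on a saturated chain carbon five bonds along the chain from an amine nitrogen in a ring, therefore does respond to what is placed there, and a group of 11 heavy atoms is accepted with a lower number rather than merely without loss. No supporting data are available to explain this result.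

The change to compound 4 brings in the rings and the 2 double bonds outside aromatic rings and replaces the hydroxy-bearing end, so the compounds shown cannot assign the lower number to any one of these features. A plain phenyl group, an amine or a carboxylic acid at the same place would help separate them, and a shorter or longer chain would show whether the distance from the amine nitrogen matters.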